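Sulfonyl sulfur group swap: from compound 2 to compound 3

A few compounds are considered here, and "the series" means these few. Any claim that something is new, unique, unknown or untested is made for them only; others in the source may bear on it.

In a physicochemical assay for solubility, in phosphate buffer, with a stated time of 24 h, at pH 7.4, tested at 100 uM (on this read-out lower numbers stand for lower solubility and higher numbers for higher solubility), compound 1 (`O=C(NCc1ccc(S(=O)(=O)c2ccccc2)cc1)N1Cc2ccncc2C1`) gives 115000 nM and compound 2 (`O=C(NCc1ccc(S(=O)(=O)N2CC3(CCOCC3)C2)cc1)N1Cc2ccncc2C1`) gives 272000 nM as the higher of the two numbers. The change to compound 3 (`O=C(NCc1ccc(S(=O)(=O)N2CCC(N3CCCC3)CC2)cc1)N1Cc2ccncc2C1`) is a group of 11 heavy atoms (9 carbon, 2 nitrogen; one five-membered non-aromatic ring with 1 hetero atom, one six-membered non-aromatic ring with 1 hetero atom) in place of a group of 9 heavy atoms (7 carbon, 1 nitrogen, 1 oxygen; one four-membered non-aromatic ring with 1 hetero atom, one six-membered non-aromatic ring with 1 hetero atom), on a sulfonyl sulfur and brings in 4-(pyrrolidin-1-yl)piperidin-1-yl on a sulfonyl sulfur whose other neighbours are: aromatic carbon. Among the measured compounds shown here, only one measured step bears on this place: a 2.4-fold higher number from compound 1 to compound 2 (0.37 log units; beyond the scatter) is modest and also falls on a sulfonyl sulfur. A single step sets no trend, and that step involves a different incoming group, so no shift beyond the scatter is expected in this assay and no direction is favoured. The estimated step is a 1.1-fold higher number from compound 2 to compound 3 (0.04 log units; within the scatter) and remains tentative. Compound 3 is expected at 300000 nM within an estimated range from 140000 nM to 550000 nM on this measure.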

Compound 3, solubility: 6200 nM
Compound 3: middle estimate off by 48-fold (1.68 log units), on the high side; measured number below the stated range.
By their numbers in this assay, from the lowest: compound 3; then compound 1; then compound 2.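

In this assay, the group on the sulfonyl sulfur can move the number much further than the first step suggested: 4-(pyrrolidin-1-yl)piperidin-1-yl gives a large drop (a 44-fold lower number from compound 2 to compound 3 (1.64 log units; beyond the scatter)), set against the modest rise seen earlier (a 2.4-fold higher number from compound 1 to compound 2 (0.37 log units; beyond the scatter)). The same group also falls well short of phenyl (a 19-fold lower number from compound 1 to compound 3 (1.27 log units; beyond the scatter)), so a non-aromatic group on this sulfur does not raise the number as a rule: compound 2 goes up from phenyl, while compound 3 goes down. Nothing available accounts for this drop.

Open, from the compounds shown here alone, is whether the drop follows the pyrrolidine ring or the piperidine ring that carries it. Going by these compounds, a plain piperidin-1-yl or a morpholin-4-yl on the same sulfur would separate the two, and the direction of its step remains unknown.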